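The source may report more compounds than this note shows. Statements on the series, on what has been measured and on what is new or still open speak of the compounds shown alone.

Two compounds have a number in a physicochemical assay for lipophilicity (on this read-out higher numbers stand for higher lipophilicity and lower numbers for lower lipophilicity), so far. Compound 1 `C=CC(=O)CCC(=O)OCC(O)COc1ccccc1C` gives 2.16 in this assay, and compound 2 `Cc1ccccc1OCC(O)COC(=O)CCC(=O)/C=C/OC[C@H]1OC(O)[C@H](O)[C@@H](O)[C@@H]1O` gives 0.04, which stands lowest of the two; the gap between them lies beyond the scatter. Compound 3 `O=C(/C=C/OC[C@H]1OC(O)[C@H](O)[C@@H](O)[C@@H]1O)CCC(=O)OCC(O)COc1ccc(Cl)cc1` differs from compound 2 by one change: 4-chlorophenyl in place of 2-methylphenyl on an oxygen on a saturated carbon. Nothing measured here shows how this exchange moves the read-out, so the expectation rests on the change alone: the step from compound 2 to compound 3 in this assay is expected to be small and upward, at about a number 0.21 log units higher from compound 2 to compound 3 (within the scatter), close to the scatter. Compound 3 is thus estimated at 0.25, within a range of -0.3 to 0.8.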

Compound 3, partition coefficient: 0.02
Estimate against measurement, compound 3: 0.23 log units above; measured number inside the range.
By their numbers in this assay, from the lowest: compounds 3 and 2 (each within the scatter of the next); then compound 1.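

In this assay the exchange of 2-methylphenyl for 4-chlorophenyl on an oxygen on a saturated carbon comes to a number 0.02 log units lower from compound 2 to compound 3 (within the scatter), so the two groups are not told apart here. Going by these compounds alone, compounds 1 and 2 both carry 2-methylphenyl, so this is the first reading of any change at this place. No supporting data bear on why the two compounds read alike. On these data alone, whether a phenyl carrying an amine or a carboxylic acid would stay as close remains open. So does whether this same exchange would give so small a step on the core of compound 1.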